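Swapping a Dichlorophenyl Pattern on a Shared Core

The compounds below may be only part of what the source reports. "The series", "measured", "known", "first", "only" and "open" are said of these compounds alone.

Compound 1, `COc1cccc(/C=C2\CCC/C(=C\c3cccc(Cl)c3Cl)C2=O)c1OC`, gives 16300 nM in a functional assay on SW-620 cells (Homo sapiens) for cytotoxicity, read by MTT assay, with a stated time of 72 h; on this read-out lower numbers stand for stronger inhibition and higher numbers for weaker inhibition.
Compound 2, `COc1cccc(/C=C2\CCC/C(=C\c3ccc(Cl)cc3Cl)C2=O)c1OC`, gives 16300 nM in this assay.
Compound 3, `COc1ccc(/C=C2\CCC/C(=C\c3cccc(Cl)c3Cl)C2=O)cc1OC`, gives 10800 nM in this assay.

Of the compounds shown here, three have been measured in this assay. Compound 1 and compound 2 differ by 2,4-dichlorophenyl in place of 2,3-dichlorophenyl on a double-bonded chain carbon bound to a double-bonded ring carbon, and the change made no change at the digits printed from compound 1 to compound 2 (within the scatter). Compound 3 carries a different arrangement on the other aryl group of the core; how the two cores differ is not broken down here, and the values of compound 1 and compound 3 lie within the scatter of each other.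

Compound 4, `COc1ccc(/C=C2\CCC/C(=C\c3ccc(Cl)cc3Cl)C2=O)cc1OC`, has not been measured. It differs from compound 3 by 2,4-dichlorophenyl in place of 2,3-dichlorophenyl on a double-bonded chain carbon bound to a double-bonded ring carbon, the same change that turned compound 1 into compound 2. Because no change at the digits printed from compound 1 to compound 2 (within the scatter), the step of a 1.0-fold higher number from compound 3 to compound 4 (0.01 log units; within the scatter) is expected to be small as well, resting on the value of compound 3, 10800 nM. Compound 4 is therefore estimated at 11000 nM, expected to lie between 5500 nM and 22000 nM.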

Compound 4, half-maximal inhibitory concentration: 10300 nM
Compound 4: the middle estimate sits 1.1-fold (0.03 log units) above what was measured, and the stated range covers the measured number.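

In this assay, putting 2,4-dichlorophenyl in place of 2,3-dichlorophenyl on the second core gave a 1.0-fold lower number from compound 3 to compound 4 (0.02 log units; within the scatter). Set beside the earlier step, the swap reads the same on both cores: the same change on two cores in this assay, no change at the digits printed (within the scatter) from compound 1 to compound 2 and a 1.0-fold lower number (0.02 log units; within the scatter) from compound 3 to compound 4, 1.0-fold (0.02 log units) apart, within the scatter of two such steps This shows that the change carried from one core to the other without a step beyond the scatter, but it rests on just two cores and one swap, so it does not show that the change would stay as small on any other core or that the placing of the chlorines never matters in this series.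

The compounds shown leave open what happens when the chlorines themselves are replaced, for example by a nitrile, a carboxylic acid or an amine on that aryl group. They also leave open whether the same swap would stay as small in a cell line other than the one used here.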